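A few compounds are considered here, and "the series" means these few. Any claim that something is new, unique, unknown or untested is made for them only; others in the source may bear on it.

Measured in an assay on liver for inhibition of sterol O-acyltransferase 1 (Rattus norvegicus), using microsomes; a lower number here means a stronger inhibitor, a higher number a weaker inhibitor:

Compound 1, `CC(C)c1cccc(C(C)C)c1OC(=O)NS(=O)(=O)Oc1ccc(F)cc1F`, gives > 50000 nM.
Compound 2, `CC(C)c1cccc(C(C)C)c1OC(=O)NS(=O)(=O)Oc1c(F)cccc1F`, gives 38000 nM.
Compound 3, `CC(C)c1cccc(C(C)C)c1OS(=O)(=O)NC(=O)Oc1ccc(F)cc1F`, gives > 50000 nM.

The value of compound 1 in this assay is a limit of the assay, not a number. The value of compound 3 is likewise a limit. Two of the three values sit at the limit of > 50000 nM in this assay, at which 2 of the 3 values shown sit. Only compound 2 gives a number, and that number is a high one, so all three compounds are weak inhibitors in this assay.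

Compound 1 and compound 2 share a core and differ in one place: 2,6-difluorophenyl in place of 2,4-difluorophenyl on an oxygen. This change gives an at least 1.3-fold lower number from compound 1 to compound 2 (0.11 log units; that floor lies within the scatter), a step that cannot be read as a real difference.

Compound 3 carries the same atoms as compound 1 joined differently, and the difference between the two cores is not broken down here.

Compound 4, `CC(C)c1cccc(C(C)C)c1OS(=O)(=O)NC(=O)Oc1c(F)cccc1F`, has not yet been measured in this assay. It stands to compound 3 as compound 2 stands to compound 1: 2,6-difluorophenyl in place of 2,4-difluorophenyl on an oxygen next to a carbonyl group. The surroundings differ, however, since in compound 1 the oxygen is bonded to a sulfonyl sulfur, whereas in compound 3 it sits next to a carbonyl group, so this is the same kind of change rather than the same change.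

Among the compounds with values here, from the step of compound 1 to compound 2 in this assay, no more than a step within the scatter is expected, and compound 4 is estimated to remain a weak inhibitor, most likely again at a limit. The expected step is a step that the limit leaves unreadable from compound 3 to compound 4, and the estimate for compound 4 is 60000 nM, between 25000 nM and 200000 nM.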

Compound 4, half-maximal inhibitory concentration: 65000 nM
Compound 4: the middle estimate sits 1.1-fold (0.03 log units) below what was measured; the range from low to high includes it.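

Within the data shown here, the value of compound 3 in this assay is a limit of the assay, not a number, and no step from compound 3 to compound 4 can be read from it. The compounds shown leave open how the two cores compare as inhibitors, and whether any change to these compounds would give a much lower number than those seen here.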